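Swapping furan-2-yl for (1H-indol-3-yl)methyl at an assay limit

The source may report more compounds than this note shows. Statements on the series, on what has been measured and on what is new or still open speak of the compounds shown alone.

Of the compounds shown here, three sharing one core have been tested in a functional assay on L5178Y cells (Mus musculus) for inhibition, read by MTT assay, with a stated time of 24 h; on this read-out lower numbers stand for stronger inhibition and higher numbers for weaker inhibition. Compound 1 `N/N=C1\C[C@@H](c2ccc(O)cc2)Oc2cc(O)cc(O)c21`, with a hydrogen on the amine nitrogen, gives >= 11300 nM, which is a limit and not a number. Compound 2 `O=C(N/N=C1\C[C@@H](c2ccc(O)cc2)Oc2cc(O)cc(O)c21)c1cccs1`, with (thiophen-2-yl)carbonyl on that nitrogen, gives >= 11300 nM, again a limit. Compound 3 `O=C(N/N=C1\C[C@@H](c2ccc(O)cc2)Oc2cc(O)cc(O)c21)c1ccco1`, with (furan-2-yl)carbonyl there, gives >= 11300 nM, also a limit. Compound 3 therefore stands with the others at the limit of >= 11300 nM in this assay, at which 3 of the 3 values shown sit.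

Compound 4 `O=C(Cc1c[nH]c2ccccc12)N/N=C1\C[C@@H](c2ccc(O)cc2)Oc2cc(O)cc(O)c21` puts (1H-indol-3-yl)methyl in place of furan-2-yl on the carbonyl carbon, a larger change than any made so far: (1H-indol-3-yl)methyl in place of furan-2-yl on a carbonyl carbon. The closest measured change, at the same carbonyl carbon, is a step that the two limits leave unreadable from compound 2 to compound 3. The changes on the amine nitrogen are a step that the two limits leave unreadable from compound 1 to compound 2 and a step that the two limits leave unreadable from compound 1 to compound 3. None of these three has a readable size, so they give no measured direction for the new group.

The expected change is therefore small and of uncertain direction, written here as a step that the limit leaves unreadable from compound 3 to compound 4, and another limit is quite likely. For compound 4 the estimate is 13000 nM, with an expected range from 5000 nM to 30000 nM.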

Compound 4, half-maximal inhibitory concentration: >= 11300 nM
Compound 4 ended at the assay's limit; the forecaster's own chance of this, stated with the estimate: 60%; the middle value lies beyond the limit too.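

In this assay compound 4 gives >= 11300 nM, which is a limit and not a number. Its steps from compound 2 and from compound 3 therefore cannot be read, and the same limit is shared across the series: the limit of >= 11300 nM in this assay, at which 4 of the 4 values shown sit.

The compounds shown leave open whether any of these groups on the carbonyl carbon alters inhibition, and how strongly any of the four compounds inhibits.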